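Benzyl ether substituent swap: nitro to methoxy

The source may hold more compounds than are shown below. What is called first, only, known or untested is meant among the compounds shown, and "the series" means these compounds.

The three measured compounds share one core and differ only in the group carried on the benzyl ether ring. Compound 1 `COc1cccc(OC)c1OCCNCCOc1ccccc1OCc1ccccc1Cl` gives 1.41 nM in an assay on CHO cells for displacement of a labelled ligand from Alpha-1A adrenergic receptor (Homo sapiens); on this read-out higher numbers stand for weaker inhibition and lower numbers for stronger inhibition. Compound 2 `COc1cccc(OC)c1OCCNCCOc1ccccc1OCc1ccc(C)cc1` gives 2 nM in this assay. Compound 3 `COc1cccc(OC)c1OCCNCCOc1ccccc1OCc1ccccc1[N+](=O)[O-]` gives 7.94 nM, the highest of the three numbers; the steps leading to it are a 4.0-fold higher number from compound 2 to compound 3 (0.60 log units; beyond the scatter) and a 5.6-fold higher number from compound 1 to compound 3 (0.75 log units; beyond the scatter), both modest and both beyond the scatter.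

Compound 4 `COc1ccccc1COc1ccccc1OCCNCCOc1c(OC)cccc1OC` differs from compound 3 by methoxy in place of nitro on an aromatic carbon. Within the data shown here, no measured step introduces a methoxy at this place, so the expectation rests on the two steps that remove groups in favour of nitro: read in reverse, a 5.6-fold higher number from compound 1 to compound 3 (0.75 log units; beyond the scatter) and a 4.0-fold higher number from compound 2 to compound 3 (0.60 log units; beyond the scatter) both lower the number by a modest amount when nitro leaves. A methoxy is expected to sit closer to chloro and methyl than to nitro on this read-out, so a modest step down is expected, a 2.6-fold lower number from compound 3 to compound 4 (0.42 log units; beyond the scatter). Compound 4 is therefore estimated at 3 nM, with a range from 1.2 nM to 8 nM.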

Compound 4, inhibition constant: 2 nM
Compound 4: the middle estimate sits 1.5-fold (0.18 log units) above what was measured; measured number inside the range.
By their numbers in this assay, from the lowest: compounds 1, 2 and 4 (each within the scatter of the next); then compound 3.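

Methoxy on this aromatic carbon, ortho to a large group, does not carry the penalty seen with nitro in this assay (a 4.0-fold lower number from compound 3 to compound 4 (0.60 log units; beyond the scatter)), so the higher number of compound 3 goes with nitro itself and not with every group at this place. Methoxy cannot be told apart from chloro at this place (a 1.4-fold higher number from compound 1 to compound 4 (0.15 log units; within the scatter)) or from the 4-methylphenyl variant (no change at the digits printed from compound 2 to compound 4 (within the scatter)), which leaves nitro as the only group of the four that stands apart. No data on hand bear on why nitro and methoxy differ here.

Open, going by these compounds, is whether an amine or a carboxylic acid at this place would group with methoxy and chloro or with nitro. Also open, on these data alone, is whether an ethoxy group, with its longer chain, would keep the number of compound 4 (2 nM).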